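Acyl urea hydrazones on A549 cells: one more variation

The source may hold more compounds than are shown below. What is called first, only, known or untested is meant among the compounds shown, and "the series" means these compounds.

Compound 1 `CN(C(=O)NC(=O)c1ccc(F)c(F)c1)c1nc(C(F)(F)F)c(C(=O)N/N=C/c2ccccc2C(F)(F)F)s1` 6.96 ug/mL
Compound 2 `CN(C(=O)NC(=O)c1ccc(C(F)(F)F)cc1)c1nc(C(F)(F)F)c(C(=O)N/N=C/c2cccc(C(F)(F)F)c2)s1` 6.66 ug/mL
Compound 3 `CN(C(=O)NC(=O)c1c(Cl)cccc1Cl)c1nc(C(F)(F)F)c(C(=O)N/N=C/c2ccccc2C(F)(F)F)s1` 12 ug/mL

In a functional assay on A549 cells (Homo sapiens) for inhibition, read by MTT assay, with a stated time of 72 h (on this read-out lower numbers stand for stronger inhibition and higher numbers for weaker inhibition), compound 3 gives the highest of the three numbers, yet its gaps to compound 1 and to compound 2 both lie within the scatter. Compound 4 `CN(C(=O)NC(=O)c1ccc(C(F)(F)F)cc1)c1nc(C(F)(F)F)c(C(=O)N/N=C/c2ccccc2C(F)(F)F)s1` has not been measured. It differs from compound 3 in one place: 4-(trifluoromethyl)phenyl in place of 2,6-dichlorophenyl on a carbonyl carbon. For the measured compounds named here, the only measured step at this position, a 1.7-fold higher number from compound 1 to compound 3 (0.24 log units; within the scatter), stayed within the scatter. Compound 2, which carries the same 4-(trifluoromethyl)phenyl group, gives 6.66 ug/mL, close to compound 1. The change from compound 3 to compound 4 is therefore expected to bring no step beyond the scatter, at most a slight drift downward, a 1.6-fold lower number from compound 3 to compound 4 (0.20 log units; within the scatter). Compound 4 is estimated at 7.5 ug/mL, with a range from 3.5 ug/mL to 16 ug/mL.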

Compound 4, half-maximal inhibitory concentration: 6.68 ug/mL
The estimate for compound 4 lay 1.1-fold (0.05 log units) above the measured number, within the range that was stated.
By their numbers in this assay, from the lowest: compounds 2, 4, 1 and 3 (each within the scatter of the next).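

In this assay, 4-(trifluoromethyl)phenyl in place of 2,6-dichlorophenyl on the carbonyl carbon gives a 1.8-fold lower number from compound 3 to compound 4 (0.25 log units; within the scatter) and in place of 3,4-difluorophenyl gives a 1.0-fold lower number from compound 1 to compound 4 (0.02 log units; within the scatter). The three groups at this position thus show no separation beyond the scatter. For the compounds shown here, the compounds also give a first step at the other end of the molecule: 2-(trifluoromethyl)phenyl in place of 3-(trifluoromethyl)phenyl on the carbon with a double bond to nitrogen gives a 1.0-fold higher number from compound 2 to compound 4 (0.00 log units; within the scatter).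

No evidence is available that bears on these results. On these data alone, whether an amine or a carboxylic acid on this carbonyl carbon would also stay within the scatter remains open.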